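Acetyl in place of a four-atom group: working notes

A few compounds are considered here, and "the series" means these few. Any claim that something is new, unique, unknown or untested is made for them only; others in the source may bear on it.

Measured in a functional assay on the whole organism (strain albino) for inhibition, with Rattus norvegicus as the target, read by paw edema, with stated times of 30 min and 5 h, at a dose of 0.28 mmol/kg by the oral route; on this read-out higher numbers stand for more inhibition at the one dose given (going by the name of the read-out) and lower numbers for less inhibition:
- compound 1, `COc1cc(-c2nnc(SCC(=O)Nc3ccc(/C(C)=N/O)cc3)n2-c2ccccc2)cc(OC)c1OC`, gives 70%
- compound 2, `CCn1c(SCC(=O)Nc2ccc(/C(C)=N/O)cc2)nnc1-c1ccccc1`, gives 66%
- compound 3, `COc1cc(-c2nnc(SCC(=O)Nc3ccc(C(C)=O)cc3)n2-c2ccccc2)cc(OC)c1OC`, gives 63%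

The three values lie close together; the gaps between compound 1, compound 2 and compound 3 are all within the usual scatter of this assay, so no order among them can be stated. Compound 2 carries a different core from compound 1; the difference between the two cores is not broken down here.

Compound 3 is compound 1 with one change, (a group of 3 heavy atoms (2 carbon, 1 oxygen; no ring) in place of a group of 4 heavy atoms (2 carbon, 1 nitrogen, 1 oxygen; no ring), on an aromatic carbon). That change gave a number 7 percentage points lower from compound 1 to compound 3 (within the scatter).

Compound 4, `CCn1c(SCC(=O)Nc2ccc(C(C)=O)cc2)nnc1-c1ccccc1`, is not yet measured. It is compound 2 with the same change, (a group of 3 heavy atoms (2 carbon, 1 oxygen; no ring) in place of a group of 4 heavy atoms (2 carbon, 1 nitrogen, 1 oxygen; no ring), on an aromatic carbon); the surroundings of the place are described in the same words for both pairs, so this is taken as the same change on the other core.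

Going by the values given here, for compound 4 in this assay the step is expected to be a number 6 percentage points lower from compound 2 to compound 4 (within the scatter), resting on the one measured instance of the change, which gave a number 7 percentage points lower from compound 1 to compound 3 (within the scatter), and on compound 2 at 66%. Compound 4 is thus estimated at 60%, with a range from 48% to 72%.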

Compound 4, a percentage reported as inhibition, in the whole organism at one dose (the size of the read-out at that dose, not a potency): 66%
Estimate against measurement, compound 4: 6 percentage points below; the range from low to high includes it.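

In this assay, acetyl in place of the four-atom group on the aromatic carbon gave no change at the digits printed from compound 2 to compound 4 (within the scatter) and, set beside the earlier step on the core of compound 1, the two readings do not separate: the same change on two cores in this assay, a number 7 percentage points lower (within the scatter) from compound 1 to compound 3 and no change at the digits printed (within the scatter) from compound 2 to compound 4, 7 percentage points apart, within the scatter of two such steps.

On these two cores, then, the change carries over with neither step beyond the scatter. This does not show that acetyl and the four-atom group are interchangeable in general, since it rests on two pairs at a single dose, and a small dependence on the core would go unseen at this scatter.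

The compounds shown leave open whether anything at that place on the aromatic ring is needed, as only these two groups occur there and a plain hydrogen, an amine or a carboxylic acid would test it. Also open, going by these compounds, is whether the step holds on further cores, for instance with a longer chain in the core of compound 2.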